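Amine-chain change from compound 3 to compound 4

The compounds below may be only part of what the source reports. "The series", "measured", "known", "first", "only" and "open" are said of these compounds alone.

Measured so far in a functional assay for antagonist activity, with Cavia porcellus as the target; a lower number here means a stronger inhibitor, a higher number a weaker inhibitor
Compound 1 `CN(CC#CCCC1(C(O)(c2ccccc2)c2ccccc2)SCCCS1)Cc1ccccc1` gives 3170 nM
Compound 2 `CN(C)CC#CCCC1(C(O)(c2ccccc2)c2ccccc2)SCCCS1` gives 1810 nM
Compound 3 `CCN(C)CC#CCCC1(C(O)(c2ccccc2)c2ccccc2)SCCCS1` gives 1230 nM

The measured series spans a narrow range. Within the data shown here, the only step beyond the scatter is a 2.6-fold lower number from compound 1 to compound 3 (0.41 log units; beyond the scatter) and it places compound 3 clearly under compound 1 alone. By contrast, a 1.5-fold lower number from compound 2 to compound 3 (0.17 log units; within the scatter) leaves no separation, and a 1.8-fold lower number from compound 1 to compound 2 (0.24 log units; within the scatter) also stays inside the scatter.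

The next compound is compound 4 `CCCN(CC#CCCCC1(C(O)(c2ccccc2)c2ccccc2)SCCCS1)CCC` and the change is a group of 11 heavy atoms (10 carbon, 1 nitrogen; no ring) in place of a group of 7 heavy atoms (6 carbon, 1 nitrogen; no ring), on a saturated chain carbon, two bonds along the chain from a saturated ring carbon in the shared core. Neither group contains a ring, and both contain a triple bond.

The measured steps bear on this only in part. Each one alters a single substituent on a saturated chain carbon bound to an amine nitrogen, and none tests a change like this one. The one clear signal is a 2.6-fold lower number from compound 1 to compound 3 (0.41 log units; beyond the scatter) where the compound with the phenyl group has the higher number. Read in reverse, this hints at a modest rise for a larger group. Compound 2 and compound 3 give no support for a trend, as a 1.5-fold lower number from compound 2 to compound 3 (0.17 log units; within the scatter) shows.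

A small rise is therefore expected, with an estimated 1.6-fold higher number from compound 3 to compound 4 (0.21 log units; within the scatter) in this assay as the working figure. Compound 4 is expected at 2000 nM (estimated range 700 nM to 6000 nM).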

Compound 4, antagonist equilibrium constant: 560 nM
For compound 4 the middle estimate is 3.6-fold (0.55 log units) above the measured one; the whole stated range lies above it.
By their numbers in this assay, from the lowest: compound 4; then compounds 3, 2 and 1 (each within the scatter of the next, the first and the last beyond it).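

In this assay, the group of 11 heavy atoms (10 carbon, 1 nitrogen; no ring) gives a 2.2-fold lower number from compound 3 to compound 4 (0.34 log units; beyond the scatter) and a 3.2-fold lower number from compound 2 to compound 4 (0.51 log units; beyond the scatter), so both steps to compound 4 pass beyond the scatter, on a saturated chain carbon, two bonds along the chain from a saturated ring carbon. Among these compounds, a larger group without a ring is therefore tolerated at this place and goes with a lower number, which the earlier compounds did not show; compound 1, with its phenyl group, goes against any reading of size alone, and compounds 2 and 3 cannot be ordered. No measurement shown accounts for this change.

The group that enters alters both the substituents on the amine and the length of the chain, so the share of each remains unresolved. Two propyl groups on the amine with the shorter chain of compound 3, or the dimethylamine of compound 2 with the longer chain of compound 4, would separate the two, and a pyrrolidine in place of the open-chain amine would show whether a ring is accepted when it contains the nitrogen.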